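The source may hold more compounds than are shown below. What is called first, only, known or untested is meant among the compounds shown, and "the series" means these compounds.

Compound 2 `CCOc1cc(C(Nc2ccc3c(N)nccc3c2)C(=O)NS(=O)(=O)c2cccc(CO)c2)ccc1OC(C)C` was tested in an assay on isolated protein for inhibition of Trypsin (Homo sapiens) (a higher number here means a weaker inhibitor, a lower number a stronger inhibitor), where compound 2 gives > 5000 nM; this is a limit of the assay, not a number. Its companion, compound 1 `CCOc1cc([C@@H](Nc2ccc3cnccc3c2)C(=O)NS(=O)(=O)c2ccccc2)ccc1OC(C)C`, is in the same position: in this assay compound 1 gives > 5000 nM, again a limit. Among the compounds with values here, the account therefore has no resolved value to stand on: the limit of > 5000 nM in this assay, at which 2 of the 2 values shown sit, is all that the two measurements show, and no step between them can be sized.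

The next compound, compound 3 `CCOc1cc(C(Nc2ccc3c(N)nccc3c2)C(=O)NS(=O)(=O)c2ccc(O)cc2)ccc1OC(C)C`, changes only the aryl on the sulfonyl: 4-hydroxyphenyl in place of 3-(hydroxymethyl)phenyl on a sulfonyl sulfur. Both groups carry one hydrogen-bond donor and one acceptor and sit on the same sulfonyl sulfur, so the change is modest in scale. Within the data shown here, with compound 2 at a limit and compound 1 at the same limit, there is no measured step from which a direction could be read. The author expects the step that the limit leaves unreadable from compound 2 to compound 3 to be none beyond the scatter, and most likely the assay will again report only a limit. The estimate for compound 3 in this assay is 9000 nM, with a range from 2500 nM to 40000 nM.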

Compound 3, inhibition constant: > 5000 nM
Compound 3: only a limit was reported (the forecaster's own chance of this, stated with the estimate: 75%); the middle value does not contradict the limit.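

In this assay, within the data shown here, compound 3 gives > 5000 nM, which is a limit of the assay and not a number, and no step from compound 2 to compound 3 can be read. The compounds shown leave open how strongly compound 1, compound 2 and compound 3 inhibit the enzyme, and whether 4-hydroxyphenyl and 3-(hydroxymethyl)phenyl on a sulfonyl sulfur differ at all.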